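The compounds below may be only part of what the source reports. "The series", "measured", "known", "first", "only" and "open" are said of these compounds alone.

Measured so far:
compound 1 `Cc1ccccc1/C(CCN1CCN(c2ccccn2)CC1)=N/O` — 4.2 nM
compound 2 `CO/N=C(\CCN1CCN(c2ccccn2)CC1)c1ccccc1C` — 74 nM

In a functional assay on HEK293 cells with D(4) dopamine receptor (Homo sapiens) as the target, read by FLIPR (a lower number here means that less compound is needed, a higher number that more compound is needed for the effect), compound 1 gives 4.2 nM. Within the data shown here, compound 2 gives 74 nM, the higher of the two numbers seen so far; the only step recorded, a methyl in place of hydrogen on an oxygen, moves the number an 18-fold higher number from compound 1 to compound 2 (1.25 log units; beyond the scatter).

Compound 3 `CO/N=C(\CCN1CCN(c2ccccn2)CC1)c1ccc(Cl)cc1Cl` is not yet measured. It differs from compound 2 by 2,4-dichlorophenyl in place of 2-methylphenyl on a carbon with a double bond to nitrogen. Among the measured compounds shown here, no measured step touches the aromatic ring on that carbon: the one step on record, from compound 1 to compound 2, concerns only the oxygen substituent, so it gives no direct guide to the size or direction of this change. Absent any such guide, no step beyond the scatter is assumed for this assay in either direction, and the expectation rests on compound 2 as the nearest measured point with its value 74 nM. Compound 3 is therefore estimated at 60 nM, within the range 15 nM to 250 nM, which amounts to an expected step of a 1.2-fold lower number from compound 2 to compound 3 (0.09 log units; within the scatter).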

Compound 3, half-maximal effective concentration: 249 nM
Beside the measured number, compound 3's estimate is 4.2-fold (0.62 log units) below it; the range from low to high includes it.
By their numbers in this assay, from the lowest: compound 1; then compound 2; then compound 3.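

In this assay, the aromatic ring on the carbon with a double bond to nitrogen proves to be a position that responds to change, which the earlier pair could not show since it varied only the oxygen substituent: 2,4-dichlorophenyl in place of 2-methylphenyl gives a 3.4-fold higher number from compound 2 to compound 3 (0.53 log units; beyond the scatter). This step is beyond the scatter but modest, and the change on the oxygen, an 18-fold higher number from compound 1 to compound 2 (1.25 log units; beyond the scatter), remains the larger of the two steps on record. No measurement on hand offers an explanation for the step at this position.

Because the step removes a methyl group and adds two chlorine atoms in a single change, the compounds shown cannot assign it to either the loss or the gain, and a phenyl ring with no substituent or one carrying a single chlorine or a methoxy group would be needed to separate these contributions. On these data alone, it also remains open whether 2,4-dichlorophenyl would give a step of similar size and direction with hydrogen rather than methyl on the oxygen, as the two changes have not been seen together in a pair differing in one place.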